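This account rests on a few compounds, and the source may have more. Where it says the series, first, only, none or still open, it means among the compounds named here.

Of the compounds shown here, two sharing one core have been measured in a functional assay on K562 cells (Homo sapiens) for antiproliferative activity, read by luminescence, with a stated time of 72 h; on this read-out higher numbers stand for weaker inhibition and lower numbers for stronger inhibition. There, compound 1 (`CN1CC=C(c2c(O)cc(O)c3c(=O)cc(-c4ccc(Sc5nc6ccccc6[nH]5)cc4)oc23)CC1`) gives 194 nM and compound 2 (`CN1CC=C(c2c(O)cc(O)c3c(=O)cc(-c4ccc(Sc5nc6ccccc6n5C)cc4)oc23)CC1`) gives 345 nM. For the measured compounds named here, compound 2 therefore stands within the scatter of compound 1, its only neighbour on these numbers, and the two cannot be ranked. Compound 3 (`CN1CC=C(c2c(O)cc(O)c3c(=O)cc(-c4ccc(Sc5nc(-c6ccccc6)c[nH]5)cc4)oc23)CC1`) has not yet been measured. It differs from compound 2 in the group on the sulfur, with 4-phenyl-1H-imidazol-2-yl in place of 1-methyl-1H-benzimidazol-2-yl (4-phenyl-1H-imidazol-2-yl in place of 1-methyl-1H-benzimidazol-2-yl on a sulfur). Going by the values given here, only one measured step bears on this change, methyl in place of hydrogen on an aromatic nitrogen, and it covers just part of it. Among the compounds with values here, no measured compound carries the entering group, so the range must stay wide. Given a 1.8-fold higher number from compound 1 to compound 2 (0.25 log units; within the scatter), no step beyond the scatter is expected in this assay, and no firm direction can be assigned. The expected change is a 1.3-fold lower number from compound 2 to compound 3 (0.12 log units; within the scatter), which remains an estimate. For compound 3 the estimated value is 260 nM, with an expected range from 80 nM to 850 nM.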

Compound 3, half-maximal inhibitory concentration: 300 nM
For compound 3 the middle estimate is 1.2-fold (0.06 log units) below the measured one, and the stated range covers the measured number.
By their numbers in this assay, from the lowest: compounds 1, 3 and 2 (each within the scatter of the next).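

Compound 3 extends the earlier picture from a methyl on an aromatic nitrogen to an exchange of the whole group on the sulfur. In this assay the change to 4-phenyl-1H-imidazol-2-yl from 1-methyl-1H-benzimidazol-2-yl gives a 1.2-fold lower number from compound 2 to compound 3 (0.06 log units; within the scatter) and the change from 1H-benzimidazol-2-yl gives a 1.5-fold higher number from compound 1 to compound 3 (0.19 log units; within the scatter) so neither exchange can be told from repeated measurement, and the three compounds cannot be ranked at this position. The two groups leaving and the one entering all count one five-membered aromatic ring with 2 hetero atoms and one six-membered aromatic ring of carbon only, and no information is available on why the numbers stay so close. 

From the compounds shown here alone, all three compounds keep such a two-ring aromatic group on the sulfur, so it remains open whether a carboxylic acid or a dimethylamino chain in its place would leave the number within the same scatter. Going by these compounds, it is also open whether a methyl on the aromatic nitrogen of 4-phenyl-1H-imidazol-2-yl, or a chlorine on its phenyl, would shift the number in this assay.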